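Arylsulfonyl piperidines: azepane in place of methylpiperazine

The source may hold more compounds than are shown below. What is called first, only, known or untested is meant among the compounds shown, and "the series" means these compounds.

The series shares a sulfonyl-piperidine core carrying a basic ring on a saturated ring carbon. Compound 1 `Cc1cc(C)c(S(=O)(=O)N2CCC(N3CCN(C)CC3)CC2)c(C)c1` has the 4-methylpiperazin-1-yl group there. In an ADME assay on HCT-116 cells (Homo sapiens) for cytotoxicity, read by CellTiter-Glo, with a stated time of 72 h (a higher number here means a weaker inhibitor, a lower number a stronger inhibitor), compound 1 gives > 5000 nM, which is a limit of the assay and not a number. Compound 2 `CC1CCN(C2CCN(S(=O)(=O)c3cc(F)c(Br)c(F)c3)CC2)CC1` is measured in this assay at > 5000 nM, again a limit. Compound 3 `Cc1cc(C)c(S(=O)(=O)N2CCC(N3CCC(c4ccccc4)CC3)CC2)c(C)c1` is measured in this assay at > 5000 nM, also a limit. Among the measured compounds shown here, all of the values reached so far sit at the limit of > 5000 nM in this assay, at which 3 of the 3 values shown sit, so no step between measured compounds can be read. Compound 4 `Cc1cc(C)c(S(=O)(=O)N2CCC(N3CCCCCC3)CC2)c(C)c1` differs from compound 1 in one place: azepan-1-yl in place of 4-methylpiperazin-1-yl on a saturated ring carbon. For the measured compounds named here, no measured pair shows what this change does in this assay. Since every neighbour stays at the limit, the step that the limit leaves unreadable from compound 1 to compound 4 is expected to be none beyond the usual scatter. Compound 4 is therefore estimated at 8000 nM, within a range from 4000 nM to 20000 nM, and most likely it will again be reported only as a limit.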

Compound 4, half-maximal inhibitory concentration: > 5000 nM
Compound 4: a limit, no number; the forecaster's own chance of this, stated with the estimate: 85%; the middle value is on the limit's open side.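

Among the compounds shown here, compound 4 gives > 5000 nM in this assay, which is a limit and not a number, so no step from compound 1 to compound 4 can be read: the limit of > 5000 nM in this assay, at which 4 of the 4 values shown sit. The compounds shown leave open whether azepan-1-yl in place of 4-methylpiperazin-1-yl changes anything in this assay, and none of them gives a measured number.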